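A few compounds are considered here, and "the series" means these few. Any claim that something is new, unique, unknown or untested is made for them only; others in the source may bear on it.

Compound 1 `CC(C)COc1cccc(-c2ccc(C(=O)N(Cc3cccc(OCCCCCC(=O)O)c3)C(C)C)cc2)c1`. In an ADME assay on Raji cells (Homo sapiens) for cytotoxicity, read by CellTiter-Glo and resazurin assay, with a stated time of 72 h (a higher number here means that more compound is needed for the effect, a lower number that less compound is needed), compound 1 gives > 26000 nM, which is a limit of the assay and not a number.
Compound 2 `CC(C)N(Cc1cccc(OCCCCCC(=O)O)c1)C(=O)c1ccc(-c2ccoc2)cc1`. In this assay compound 2 gives > 26000 nM, also a limit.
Compound 3 `CC(C)N(Cc1cccc(OCCCCCC(=O)O)c1)C(=O)c1ccc(-c2ccsc2)cc1`. In this assay compound 3 gives > 26000 nM, again only a limit.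

Among the compounds with values here, compound 3 therefore stands where every measured compound stands, at the limit of > 26000 nM in this assay, at which 3 of the 3 values shown sit; no compound in this set has a readable number. Compound 4 `COc1cccc(-c2ccc(C(=O)N(Cc3cccc(OCCCCCC(=O)O)c3)C(C)C)cc2)c1` differs from compound 3 in one place: 3-methoxyphenyl in place of thiophen-3-yl on an aromatic carbon. The measured steps that touch this position are a step that the two limits leave unreadable from compound 1 to compound 3, a step that the two limits leave unreadable from compound 1 to compound 2 and a step that the two limits leave unreadable from compound 2 to compound 3, and each of them is unreadable, since both ends sit at the limit. A swap of one aromatic group at this position has so far never brought a compound under the limit, and the change to compound 4 is of the same kind. In this assay compound 4 is therefore expected to give 30000 nM, with a range from 10000 nM to 100000 nM, most likely reported again as a limit. The expected step is a step that the limit leaves unreadable from compound 3 to compound 4, that is none beyond the scatter.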

Compound 4, half-maximal effective concentration: > 20900 nM
Compound 4: a limit, no number (the forecaster's own chance of this, stated with the estimate: 85%); the middle value lies beyond the limit too.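

Within the data shown here, compound 4, like compound 1, compound 2 and compound 3, gives only a limit and not a number, so no step between compound 4 and any of the others can be read. The compounds shown leave open whether any aromatic group at this position would bring a compound under the limit in this assay.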